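Ring for Ring at the Hydroxyl-Bearing Carbon

The source may hold more compounds than are shown below. What is called first, only, known or untested is meant among the compounds shown, and "the series" means these compounds.

Compound 1 `CCCCC(C)(C)[C@H](O)/C=C/C1C2CCC(O2)C1C/C=C\CCCC(=O)O`: 1100 nM
Compound 2 `O=C(O)CCC/C=C\CC1C2CCC(O2)C1/C=C/[C@@H](O)C1CCCCC1`: 400 nM

In a functional assay (plasma) for inhibition, with Homo sapiens as the target (a lower number here means a stronger inhibitor, a higher number a weaker inhibitor), compound 2 gives the lowest of the two numbers; its nearest neighbour is compound 1, and the step of a 2.8-fold lower number from compound 1 to compound 2 (0.44 log units; beyond the scatter) is beyond the scatter. Compound 3 `O=C(O)CCC/C=C\CC1C2CCC(O2)C1/C=C/[C@@H](O)CCc1ccccc1` differs from compound 2 by phenethyl in place of cyclohexyl on a saturated chain carbon bound to a double-bonded chain carbon and an oxygen on a saturated carbon. Within the data shown here, the only measured step swapped a chain for a ring; none exchanges one ring for another, so it bears on this step only loosely. A step within the scatter is therefore expected, no change at the digits printed from compound 2 to compound 3 (within the scatter). Compound 3 is estimated at 400 nM, between 150 nM and 1100 nM.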

Compound 3, half-maximal inhibitory concentration: 1200 nM
Estimate against measurement, compound 3: 3.0-fold (0.48 log units) below, outside the stated range (above it).
By their numbers in this assay, from the lowest: compound 2; then compounds 1 and 3 (each within the scatter of the next).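

In this assay the saturated chain carbon bound to a double-bonded chain carbon and an oxygen proves sensitive to which ring it carries: phenethyl in place of cyclohexyl gives a 3.0-fold higher number from compound 2 to compound 3 (0.48 log units; beyond the scatter) and so the presence of a six-membered ring alone does not secure the lower number of compound 2. With a 1.1-fold higher number from compound 1 to compound 3 (0.04 log units; within the scatter) phenethyl and 1,1-dimethylpentyl stand level. Nothing at hand explains this difference. The compounds shown leave open whether benzyl or phenyl would match cyclohexyl, and how cyclopentyl would compare.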